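This account rests on a few compounds, and the source may have more. Where it says the series, first, only, none or still open, it means among the compounds named here.

Working notes on the series. In a functional assay on EKVX cells (Homo sapiens) for inhibition, read by sulforhodamine B assay, with a stated time of 48 h (on this read-out higher numbers stand for weaker inhibition of growth and lower numbers for stronger inhibition of growth), compound 1 `COc1ccc(-c2[nH]c3ccccc3c2/C=C(\C#N)S(=O)(=O)c2ccccc2)cc1` gives 1300 nM, the lowest of the two numbers in hand. Compound 2 `CCOC(=O)C(=Cc1c(-c2ccccc2)[nH]c2ccccc12)C(=O)OCC`, with a diester in place of the nitrile sulfone, gives 12400 nM in this assay, a gap beyond the scatter. Compound 3 `COc1ccc(-c2[nH]c3ccc(OC)cc3c2C=C(C#N)C#N)cc1` carries a second methoxy on the core and a dinitrile, and this assay returned "not determined" (no result reported) for it, so it adds no number.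

Compound 4 `N#C/C(=C\c1c(-c2ccccc2)[nH]c2ccccc12)S(=O)(=O)c1ccccc1` differs from compound 1 by hydrogen in place of methoxy on an aromatic carbon. Among the measured compounds shown here, no measured pair covers this change. With only the sulfone warhead retained and the core otherwise unchanged, compound 4 is expected to remain near compound 1, with the step of a 1.5-fold higher number from compound 1 to compound 4 (0.19 log units; within the scatter) judged within or just beyond the scatter. The estimate for compound 4 in this assay is therefore 2000 nM, between 700 nM and 6000 nM.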

Compound 4, concentration for 50% growth inhibition: 6200 nM
Compound 4: middle estimate off by 3.1-fold (0.49 log units), on the low side; the whole stated range lies below it.
By their numbers in this assay, from the lowest: compound 1; then compounds 4 and 2 (each within the scatter of the next).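

In this assay, among the compounds shown here, the change 4-methoxyphenyl to phenyl gives a 4.8-fold higher number from compound 1 to compound 4 (0.68 log units; beyond the scatter) and so forms the first comparison that differs in one place. The methoxy para to a large group therefore goes with stronger inhibition of growth, though the step is modest and rests on this single pair. Nothing measured here accounts for the step.

From the compounds shown here alone, whether an amine, a hydroxyl or a longer chain such as ethoxy at this place would match the methoxy stays open. So does whether the same change gives a similar step on the diester of compound 2.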